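Replacing the 3,4-dihydroxyphenyl group of compound 3

The source may hold more compounds than are shown below. What is called first, only, known or untested is meant among the compounds shown, and "the series" means these compounds.

Measured so far in a functional assay on KB cells (Homo sapiens) for antiproliferative activity, read by sulforhodamine B assay, with a stated time of 3 days; on this read-out lower numbers stand for an effect already at smaller amounts and higher numbers for an effect only at larger amounts of compound
Compound 1 (`CCC1=C(O)c2c(oc(-c3ccc(C)cc3)cc2=O)C(CC)(CC)C1=O`) gives (39.2 uM)
Compound 2 (`CCC1=C(O)c2c(oc(-c3ccc(C(C)C)cc3)cc2=O)C(CC)(CC)C1=O`) gives (8.13 uM)
Compound 3 (`CCC1=C(O)c2c(oc(-c3ccc(O)c(O)c3)cc2=O)C(CC)(CC)C1=O`) gives (10 uM)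

Compound 3 cannot be told apart from compound 2, and both numbers lie clearly under that of compound 1. Compound 4 (`CCC1=C(O)c2c(oc(-c3cc(C)ccc3F)cc2=O)C(CC)(CC)C1=O`) keeps the shared core and carries 2-fluoro-5-methylphenyl in place of 3,4-dihydroxyphenyl on an aromatic carbon. Going by the values given here, three measured steps concern this same carbon. Isopropyl in place of methyl gave a 4.8-fold lower number from compound 1 to compound 2 (0.68 log units; beyond the scatter) and 3,4-dihydroxyphenyl in place of 4-methylphenyl gave a 3.9-fold lower number from compound 1 to compound 3 (0.59 log units; beyond the scatter) while 3,4-dihydroxyphenyl in place of 4-isopropylphenyl gave only a 1.2-fold higher number from compound 2 to compound 3 (0.09 log units; within the scatter) (within the scatter). Among the compounds with values here, no measured compound carries fluorine. Like compound 1 (39.2 uM) compound 4 has a methyl group on this phenyl and no hydroxyl groups, so a number between those of compound 3 and compound 1 seems likely. A modest rise is therefore expected, estimated as a 2.0-fold higher number from compound 3 to compound 4 (0.30 log units; within the scatter) in this assay (an uncertain step). For compound 4 the estimated value is 20 uM (expected range 7 uM to 55 uM).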

Compound 4, concentration for half-maximal effect: 47.3 uM
Compound 4: middle estimate off by 2.4-fold (0.37 log units), on the low side, and the stated range covers the measured number.
By their numbers in this assay, from the lowest: compounds 2 and 3 (each within the scatter of the next); then compounds 1 and 4 (each within the scatter of the next).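

In this assay, 2-fluoro-5-methylphenyl in place of 3,4-dihydroxyphenyl gives a 4.7-fold higher number from compound 3 to compound 4 (0.67 log units; beyond the scatter), and in place of 4-isopropylphenyl it gives a 5.8-fold higher number from compound 2 to compound 4 (0.76 log units; beyond the scatter), so this position does not treat every substituted phenyl alike. In place of 4-methylphenyl it gives only a 1.2-fold higher number from compound 1 to compound 4 (0.08 log units; within the scatter), which places compound 4 with compound 1, while compound 2 shows that lacking hydroxyl groups does not by itself lead to the higher numbers. Nothing available accounts for these differences.

Going by these compounds, compound 4 differs from compound 1 in both the fluorine and the placement of the methyl group, so the share of each remains open. On these data alone, how an amine, a carboxylic acid or a longer chain on this phenyl would behave also remains open.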